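Removing a bromo group at a second place in this series

The source may report more compounds than this note shows. Statements on the series, on what has been measured and on what is new or still open speak of the compounds shown alone.

Of the compounds shown here, three have been measured in a functional assay on MCF7 cells (Homo sapiens) for antiproliferative activity, read by sulforhodamine B assay, with a stated time of 72 h, tested at 30 uM; on this read-out higher numbers stand for a weaker effect at the one concentration tested and lower numbers for a stronger effect. Compound 1 `COC(=O)C1=C(N)Oc2c(OC)cc(Br)cc2C1CC(=O)c1ccc(Cl)cc1` gives 33.8%, compound 2 `COC(=O)C1=C(N)Oc2ccc(Br)cc2C1CC(=O)c1ccc(Br)cc1` gives 34.8%, and compound 3 `COC(=O)C1=C(N)Oc2c(OC)cccc2C1CC(=O)c1ccc(Cl)cc1` gives 63.8%. Compound 4 `COC(=O)C1=C(N)Oc2ccc(Br)cc2C1CC(=O)c1ccccc1` is not yet measured.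

Compound 3 arises from compound 1 by the change (hydrogen in place of bromo on an aromatic carbon), and this step is a number 30 percentage points higher from compound 1 to compound 3 (beyond the scatter). Compound 4 arises from compound 2 by the change (hydrogen in place of bromo on an aromatic carbon). The difference between the cores of compound 2 and compound 1 is not broken down here. The two changes are of the same kind but not the same: in the first the bromo sits on a ring that is part of a fused system, meta to a fused ring, meta to a methoxy group and para to a fused ring; in the second it sits on a six-membered aromatic ring of carbon only, para to a large group.

Beside a number 30 percentage points higher from compound 1 to compound 3 (beyond the scatter), the expected step for compound 4 is a number 17.2 percentage points higher from compound 2 to compound 4 (beyond the scatter), resting only on that single measured step at a different place. The estimate for compound 4 is 52%, between 32% and 75%.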

Compound 4, a percentage reported as activity, at one concentration (the size of the read-out at that concentration, not a potency): 41.3%
Estimate against measurement, compound 4: 10.7 percentage points above, and the stated range covers the measured number.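

In this assay, hydrogen in place of bromo on the 4-bromophenyl group gives a number 6.5 percentage points higher from compound 2 to compound 4 (within the scatter), so at this place the change cannot be told apart from the ordinary spread of repeated measurements. The change therefore does not carry from one core to the other as a step of fixed size: the same change on two cores in this assay, a number 30 percentage points higher (beyond the scatter) from compound 1 to compound 3 and a number 6.5 percentage points higher (within the scatter) from compound 2 to compound 4, 23.5 percentage points apart, beyond the scatter of two such steps This does not show why the two steps differ, as the bromo sits at a different place in each pair and the cores differ as well, and one pair on each core sets no rule for the whole series.

The compounds shown leave open whether an amine or a carboxylic acid in place of the bromo of compound 2 would shift the read-out beyond the scatter. Also open, on these data alone, is what hydrogen in place of the chloro group of compound 1 would do, which would show this kind of change on the other core.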